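The source may hold more compounds than are shown below. What is called first, only, known or untested is meant among the compounds shown, and "the series" means these compounds.

Measured compounds: compound 1 `Cc1ccc(CS/C(=C/c2c[nH]c3ccc(Cl)cc23)C(=O)c2ccc(Cl)cc2)cc1`, 1000 nM; compound 2 `Cc1ccc(CS/C(=C/c2c(O)cc(O)cc2O)C(=O)c2ccc(Cl)cc2)cc1`, 50000 nM.

In a functional assay on DU-145 cells (Homo sapiens) for inhibition, read by trypan blue exclusion, with a stated time of 96 h (on this read-out lower numbers stand for stronger inhibition of growth and higher numbers for weaker inhibition of growth), compound 2 gives the highest of the two numbers; its nearest neighbour is compound 1, with a 50-fold higher number from compound 1 to compound 2 (1.70 log units; beyond the scatter). Compound 3 `CSc1ccc(/C=C(/SCc2ccc(C)cc2)C(=O)c2ccc(Cl)cc2)cc1` differs from compound 2 by 4-(methylsulfanyl)phenyl in place of 2,4,6-trihydroxyphenyl on a double-bonded chain carbon bound to a double-bonded chain carbon. Among the measured compounds shown here, only the step from compound 1 to compound 2 bears on this: it brought the 2,4,6-trihydroxyphenyl in and the number rose strongly, so its removal in compound 3 is expected to reverse much of that, giving a 20-fold lower number from compound 2 to compound 3 (1.30 log units; beyond the scatter). Compound 3 is therefore estimated at 2500 nM, within 500 nM to 15000 nM.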

Compound 3, concentration for 50% growth inhibition: 25000 nM
Beside the measured number, compound 3's estimate is 10-fold (1.00 log units) below it, outside the stated range (above it).
By their numbers in this assay, from the lowest: compound 1; then compounds 3 and 2 (each within the scatter of the next).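

In this assay, 4-(methylsulfanyl)phenyl in place of 2,4,6-trihydroxyphenyl on a double-bonded chain carbon bound to a double-bonded chain carbon gives a 2.0-fold lower number from compound 2 to compound 3 (0.30 log units; within the scatter). These two quite different phenyl groups therefore do not separate, while the 5-chloro-1H-indol-3-yl of compound 1 stands apart from both, with a 25-fold higher number from compound 1 to compound 3 (1.40 log units; beyond the scatter). No data on hand explain why the indole stands apart.

Still open, on these data alone, is whether the chlorine of the indole matters, as the plain 1H-indol-3-yl would show. Also open, as far as these compounds go, is how a phenyl carrying an amine or a carboxylic acid would read at this place.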